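Biaryl replacement in an amide series at the bile acid receptor

The source may report more compounds than this note shows. Statements on the series, on what has been measured and on what is new or still open speak of the compounds shown alone.

Compound 1 `COC(=O)/C=C/c1cccc(N(Cc2ccc(/C=C/c3cccc(C(F)(F)F)c3)cc2)C(=O)C(C)C)c1`: 267 nM
Compound 2 `COC(=O)/C=C/c1cccc(N(Cc2ccc(/C=C/c3ccccn3)cc2)C(=O)C(C)C)c1`: 310 nM
Compound 3 `COC(=O)/C=C/c1cccc(N(Cc2ccc(-c3cccc(OC)c3)cc2)C(=O)C(C)C)c1`: 72 nM

In an assay on isolated protein with Bile acid receptor (Homo sapiens) as the target (a higher number here means that more compound is needed for the effect, a lower number that less compound is needed), compound 3 gives 72 nM and stands lowest of the three, the steps from compound 1 (a 3.7-fold lower number from compound 1 to compound 3 (0.57 log units; beyond the scatter)) and from compound 2 (a 4.3-fold lower number from compound 2 to compound 3 (0.63 log units; beyond the scatter)) both lying beyond the scatter. Compound 4 `COC(=O)/C=C/c1cccc(N(Cc2ccc(-c3ccc(F)c(Cl)c3)cc2)C(=O)C(C)C)c1` differs from compound 3 by 3-chloro-4-fluorophenyl in place of 3-methoxyphenyl on an aromatic carbon. Within the data shown here, no measured step swaps one substituent for another on a directly attached phenyl; the two steps into compound 3 concern the linker to the ring, which compound 4 keeps. Compound 4 is therefore expected near compound 3, with a step of a 1.4-fold higher number from compound 3 to compound 4 (0.14 log units; within the scatter) that may fall within the scatter. Compound 4 is estimated at 100 nM, between 35 nM and 300 nM.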

Compound 4, half-maximal effective concentration: 129 nM
Beside the measured number, compound 4's estimate is 1.3-fold (0.11 log units) below it, within the range that was stated.
By their numbers in this assay, from the lowest: compounds 3 and 4 (each within the scatter of the next); then compounds 1 and 2 (each within the scatter of the next).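

With the direct ring attachment kept and only its substituents exchanged, the step is a 1.8-fold higher number from compound 3 to compound 4 (0.25 log units; within the scatter), so in this assay this position accepts 3-chloro-4-fluorophenyl as well as 3-methoxyphenyl, although the entering group has no hydrogen-bond acceptor. The lower numbers for the directly attached phenyl over the ethenyl-linked compounds also hold for this second phenyl, with a 2.4-fold lower number from compound 2 to compound 4 (0.38 log units; beyond the scatter) and a 2.1-fold lower number from compound 1 to compound 4 (0.32 log units; beyond the scatter), both modest. Nothing measured here offers an explanation for these steps. The compounds shown leave open how an aminomethyl or carboxylic acid group on this phenyl would fare.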